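This account rests on a few compounds, and the source may have more. Where it says the series, first, only, none or still open, it means among the compounds named here.

Compound 3 `Cn1cc(-c2cc(NS(C)(=O)=O)ccc2Oc2ccc(F)cc2)n2cncc2c1=O` gives 370 nM in a functional assay on HL-60 cells (Homo sapiens) for antiproliferative activity, read by MTT assay (a higher number here means a weaker inhibitor, a lower number a stronger inhibitor), the second highest of the three numbers: compound 1 `Cn1cc(-c2cc(NS(C)(=O)=O)ccc2Oc2ccc(Br)cc2)n2cncc2c1=O` gives 230 nM, and compound 2 `CCS(=O)(=O)Nc1ccc(Oc2ccc(-c3c(C)noc3C)cc2)c(-c2cn(C)c(=O)c3cncn23)c1` gives 510 nM, both within the scatter of compound 3. Within the data shown here, the one measured single-point step, a 1.6-fold higher number from compound 1 to compound 3 (0.21 log units; within the scatter), stayed within the scatter. Compound 4 `Cc1noc(C)c1-c1ccc(Oc2ccc(NS(C)(=O)=O)cc2-c2cn(C)c(=O)c3cncn23)cc1` differs from compound 3 by 3,5-dimethyl-1,2-oxazol-4-yl in place of fluoro on an aromatic carbon. Among the measured compounds shown here, no measured step bears directly on this change; compound 2, which also carries a 3,5-dimethyl-1,2-oxazol-4-yl group though it differs from compound 3 elsewhere as well, and compound 3 show values within the scatter of each other. The step is therefore expected to be none beyond the scatter, a 1.1-fold higher number from compound 3 to compound 4 (0.06 log units; within the scatter). The estimate for compound 4 is 420 nM, with a range from 200 nM to 900 nM.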

Compound 4, half-maximal inhibitory concentration: 1120 nM
Compound 4: the middle estimate sits 2.7-fold (0.43 log units) below what was measured; the measured number lies above the stated range.
By their numbers in this assay, from the lowest: compounds 1, 3 and 2 (each within the scatter of the next, the first and the last beyond it); then compound 4.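

In this assay, 3,5-dimethyl-1,2-oxazol-4-yl in place of fluoro gave a 3.0-fold higher number from compound 3 to compound 4 (0.48 log units; beyond the scatter), and in place of bromo it gave a 4.9-fold higher number from compound 1 to compound 4 (0.69 log units; beyond the scatter), so this aromatic carbon responds to the larger ring, though the swap between the two halogens had stayed within the scatter. The sulfonyl chain also matters with this ring present: hydrogen in place of methyl on its saturated carbon gave a 2.2-fold higher number from compound 2 to compound 4 (0.34 log units; beyond the scatter). Nothing shown accounts for either change. From the compounds shown here alone, whether a methyl, a methoxy or a plain phenyl at this carbon would stay near the halogens remains open, as does whether the chain step would recur with bromo or fluoro there.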